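The compounds below may be only part of what the source reports. "The series", "measured", "known", "first", "only" and "open" are said of these compounds alone.

Working notes on the series. Two compounds have been run in a functional assay on K562 cells (Homo sapiens) for antiproliferative activity, read by MTT assay, with a stated time of 48 h; on this read-out higher numbers stand for weaker inhibition and lower numbers for stronger inhibition. Compound 1 (`CCCCc1ccc2c(c1)C(=O)C(=O)N2`) carries a butyl chain on the shared core. In this assay compound 1 gives only a limit of the assay, > 10000 nM. Compound 2 (`Cc1ccc(-c2ccc3c(c2)C(=O)C(=O)N3)cc1`) carries a methyl-bearing phenyl ring on the same core. In this assay compound 2 likewise gives only a limit of the assay, > 10000 nM. Within the data shown here, compound 2 therefore stands at the limit of > 10000 nM in this assay, at which 2 of the 2 values shown sit; no number separates it from compound 1, and no step between measured compounds can be drawn.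

Compound 3 (`COc1ccc(-c2ccc3c(c2)C(=O)C(=O)N3)cc1`) is not yet measured. It differs from compound 2 by methoxy in place of methyl on an aromatic carbon, para to a large group. With both measured compounds sitting at the limit, the exchange of methyl for methoxy gives no ground for a step beyond the scatter. The expected step in this assay is a step that the limit leaves unreadable from compound 2 to compound 3, that is, none beyond the scatter. Compound 3 is estimated at 15000 nM in this assay, with a range from 5000 nM to 50000 nM, and the assay is expected most likely to report only a limit again.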

Compound 3, half-maximal inhibitory concentration: 6920 nM
Estimate against measurement, compound 3: 2.2-fold (0.34 log units) above; measured number inside the range.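

In this assay, the exchange of methyl for methoxy on an aromatic carbon, para to a large group, gives an at least 1.4-fold lower number from compound 2 to compound 3 (0.15 log units; that floor lies within the scatter). Among these compounds, compound 3, at 6920 nM, is the first compound to give a number rather than a limit of the assay, so this position is the first place on the shared core where a change can be tied to a readable value, though that value comes from a single exchange. The true size of the step cannot be read, and the printed floor does not by itself separate the two compounds, because compound 2 sits at a limit of the assay: the limit of > 10000 nM in this assay, at which 2 of the 3 values shown sit.

From the compounds shown here alone, it remains open whether the oxygen of the methoxy group matters or whether the added heavy atom alone is enough, which a comparison with an ethyl group at the same place could address. Going by these compounds, it is equally open whether a hydroxyl group, an ethoxy group or an amine at that place would give a lower number than compound 3.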